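A few compounds are considered here, and "the series" means these few. Any claim that something is new, unique, unknown or untested is made for them only; others in the source may bear on it.

Measured in a functional assay on MCF7 cells (Homo sapiens) for inhibition, with a stated time of 48 h; a lower number here means a stronger inhibitor, a higher number a weaker inhibitor:
- compound 1 `COc1cc(Sc2c[nH]c3ccc(Br)cc23)cc(OC)c1OC`: 43 nM
- compound 2 `COc1cc(Sc2c[nH]c3ccc(F)cc23)cc(OC)c1OC`: 160 nM
- compound 3 `COc1cc(Sc2c[nH]c3ccc(C)cc23)cc(OC)c1OC`: 16 nM

Compound 3 has the lowest number of the three, ahead of both compound 1 and compound 2. Compound 4 `CCOc1ccc2[nH]cc(Sc3cc(OC)c(OC)c(OC)c3)c2c1` keeps the shared core and carries ethoxy in place of methyl on an aromatic carbon.

For the measured compounds named here, no measured compound carries ethoxy, so the evidence is indirect. All three measured steps change the group at this same place. The largest is a 10-fold lower number from compound 2 to compound 3 (1.00 log units; beyond the scatter), followed by a 3.7-fold higher number from compound 1 to compound 2 (0.57 log units; beyond the scatter) and a 2.7-fold lower number from compound 1 to compound 3 (0.43 log units; beyond the scatter). All are modest but beyond the scatter, so a step of similar size is expected here as well. The direction is less certain, but compound 3 already sits at the low end with 16 nM, so a modest rise in this assay is expected.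

The estimated step is a 3.1-fold higher number from compound 3 to compound 4 (0.49 log units; beyond the scatter). For compound 4 the expected value is 50 nM, with an estimated range of 12 nM to 200 nM.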

Compound 4, half-maximal inhibitory concentration: 16 nM
Compound 4: middle estimate off by 3.1-fold (0.49 log units), on the high side; the measured number falls inside the stated range.
By their numbers in this assay, from the lowest: compounds 3 and 4 (each within the scatter of the next); then compound 1; then compound 2.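

In this assay there is no change at the digits printed from compound 3 to compound 4 (within the scatter), so at this place on the aromatic carbon, ethoxy, with 3 heavy atoms and 1 hydrogen-bond acceptor, is tolerated as well as methyl, with 1 heavy atom and no acceptor. The halogens stay apart from it, with a 10-fold lower number from compound 2 to compound 4 (1.00 log units; beyond the scatter) and a 2.7-fold lower number from compound 1 to compound 4 (0.43 log units; beyond the scatter), so both of these steps repeat those already seen with methyl and the larger ethoxy group loses nothing against either halogen. No supporting data bear on why these two groups give such similar numbers.

The compounds shown leave open whether a longer chain such as butoxy would keep the number of compound 4 or raise it. They also leave open how methoxy, hydroxy, an amine or a carboxylic acid would behave at this place.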